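The source may hold more compounds than are shown below. What is called first, only, known or untested is meant among the compounds shown, and "the series" means these compounds.

Compound 1 `CCCc1nc(-c2ccccc2)c(CNCCCN2CCN(c3ccc(F)cc3)CC2)o1`: 3210 nM
Compound 2 `CCCc1nc(-c2ccccc2)c(CNCCCN2CCN(c3cccc(F)c3)CC2)o1`: 3030 nM
Compound 3 `CCCc1nc(-c2ccccc2)c(CNCCN2CCN(c3ccc(F)cc3)CC2)o1`: 7080 nM

All three were tested in an assay on HEK293 cells for inhibition of Voltage-dependent T-type calcium channel subunit alpha-1G (Homo sapiens), read by patch clamp; a higher number here means a weaker inhibitor, a lower number a stronger inhibitor. Compound 3 stands highest of the three numbers; compound 1 lies nearest to it and compound 2 furthest, and the gap to each of them is beyond the usual scatter. Compound 1 and compound 2 differ from each other only in the fluorophenyl group, and that change gave a 1.1-fold lower number from compound 1 to compound 2 (0.03 log units; within the scatter), which is within the scatter.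

Compound 4 `CCCc1nc(-c2ccccc2)c(CNCCN2CCN(c3cccc(F)c3)CC2)o1` has not yet been measured in this assay. It differs from compound 3 by 3-fluorophenyl in place of 4-fluorophenyl on an amine nitrogen in a ring. This is the same swap that separates compound 1 from compound 2, applied now to the pair with the shorter chain. Within the data shown here, the only measured step that bears on it is a 1.1-fold lower number from compound 1 to compound 2 (0.03 log units; within the scatter), which was too small to count as a change. On that basis compound 4 is expected to show a 1.1-fold lower number from compound 3 to compound 4 (0.02 log units; within the scatter), that is, no step beyond the scatter in either direction. The number for compound 4 in this assay is therefore estimated at 6700 nM, with a range from 3400 nM to 13000 nM.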

Compound 4, half-maximal inhibitory concentration: 3350 nM
Estimate against measurement, compound 4: 2.0-fold (0.30 log units) above, outside the stated range (below it).
By their numbers in this assay, from the lowest: compounds 2, 1 and 4 (each within the scatter of the next); then compound 3.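

In this assay, the swap to 3-fluorophenyl from 4-fluorophenyl on the amine nitrogen in a ring, which left no readable mark on the longer chain, now gives a 2.1-fold lower number from compound 3 to compound 4 (0.32 log units; beyond the scatter) on the shorter chain. With the 3-fluorophenyl group in place, compound 2 gives 3030 nM and compound 4 gives 3350 nM, two values that lie close together, so this pair shows none of the gap that the 4-fluorophenyl pair showed between its two chain lengths. Even so, the new step is modest and cannot be firmly separated from the earlier one, so a dependence of this change on the chain is suggested rather than established: the same change on two cores in this assay, a 1.1-fold lower number (0.03 log units; within the scatter) from compound 1 to compound 2 and a 2.1-fold lower number (0.32 log units; beyond the scatter) from compound 3 to compound 4, 2.0-fold (0.30 log units) apart, within the scatter of two such steps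

The compounds shown leave open whether the effect of moving the fluorine depends on chain length at all, as this rests on just two pairs. They also leave open how an unsubstituted phenyl, a chlorophenyl or a methoxyphenyl at this position would read, and whether a longer chain would follow the same trend.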